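The source may report more compounds than this note shows. Statements on the series, on what has been measured and on what is new or still open speak of the compounds shown alone.

Of the compounds shown here, two have been measured so far. Compound 1 `COC1(Cc2cccc(Cl)c2)CCN(c2ccc(C(=O)NS(=O)(=O)c3ccc(N[C@H](CCN(C)C)CSc4ccccc4)c([N+](=O)[O-])c3)cc2)CC1` gives 300 nM in a functional assay (FL5.12 cells, Mus musculus) with Apoptosis regulator Bcl-2 (Homo sapiens) as the target; on this read-out higher numbers stand for an effect only at larger amounts of compound and lower numbers for an effect already at smaller amounts. Compound 2 `CN(C)CC[C@H](CSc1ccccc1)Nc1ccc(S(=O)(=O)NC(=O)c2ccc(N3CCC(=Cc4ccc(F)cc4)CC3)cc2)cc1[N+](=O)[O-]` gives 600 nM in this assay; this is the top of the two numbers, yet its distance from compound 1 lies within the scatter of repeated measurements. Compound 3 `COc1ccccc1C=C1CCN(c2ccc(C(=O)NS(=O)(=O)c3ccc(N[C@H](CCN(C)C)CSc4ccccc4)c([N+](=O)[O-])c3)cc2)CC1` has not been measured; it differs from compound 2 by 2-methoxyphenyl in place of 4-fluorophenyl on a double-bonded chain carbon bound to a double-bonded ring carbon. For the measured compounds named here, no measured pair shows a change of this kind, so the expected step (no change at the digits printed from compound 2 to compound 3 (within the scatter)) is none beyond the scatter. Compound 3 is therefore estimated at 600 nM, with a range from 200 nM to 1800 nM.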

Compound 3, half-maximal effective concentration: 250 nM
Beside the measured number, compound 3's estimate is 2.4-fold (0.38 log units) above it; the measured number falls inside the stated range.
By their numbers in this assay, from the lowest: compounds 3, 1 and 2 (each within the scatter of the next, the first and the last beyond it).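

In this assay, this position responds to the group it carries: 2-methoxyphenyl in place of 4-fluorophenyl on a double-bonded chain carbon bound to a double-bonded ring carbon gives a 2.4-fold lower number from compound 2 to compound 3 (0.38 log units; beyond the scatter) as a modest step. Compounds 1 and 2 differ in more than one place, so they could not show this. No measurement shown gives a reason for the step.

The change replaces the group on the phenyl ring and also moves its place, and the compounds shown do not separate these two changes. On these data alone, whether 4-methoxyphenyl or 2-fluorophenyl would give a number nearer compound 2 or compound 3 remains open.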